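The source may report more compounds than this note shows. Statements on the series, on what has been measured and on what is new or still open speak of the compounds shown alone.

Compound 1, `O=C1CCCN1C1=CC(CF)(CF)Oc2ccc([N+](=O)[O-])cc21`, and compound 2, `O=C1CCCN1C1=CC(CF)(CF)Oc2ccc(C(F)(F)C(F)(F)F)cc21`, share one core and differ in a single place, (1,1,2,2,2-pentafluoroethyl in place of nitro on an aromatic carbon). In a functional assay (aorta) with Rattus norvegicus as the target (on this read-out lower numbers stand for an effect already at smaller amounts and higher numbers for an effect only at larger amounts of compound), compound 1 gives 7.76 nM, while compound 2 gives 1.51 nM, a step of a 5.1-fold lower number from compound 1 to compound 2 (0.71 log units; beyond the scatter). Compound 3, `O=C1CCCCN1[C@@H]1c2cc([N+](=O)[O-])ccc2OC(CF)(CF)[C@H]1O`, is built on a different core; how the two cores differ is not broken down here. In this assay compound 3 gives 2.75 nM, a number that lies within the scatter of compound 2 and is beyond the scatter of compound 1. Compound 4, `O=C1CCCCN1[C@@H]1c2cc(C(F)(F)C(F)(F)F)ccc2OC(CF)(CF)[C@H]1O`, carries the same change on the core of compound 3, namely (1,1,2,2,2-pentafluoroethyl in place of nitro on an aromatic carbon). Because the same change lowered the number in this assay by a 5.1-fold lower number from compound 1 to compound 2 (0.71 log units; beyond the scatter), and because compound 3 already stands at 2.75 nM, compound 4 is expected to show a step of a 3.1-fold lower number from compound 3 to compound 4 (0.49 log units; beyond the scatter), somewhat smaller than the earlier one since it rests on a single example on another core. The expected number for compound 4 in this assay is 0.9 nM, with a range from 0.3 nM to 2.5 nM.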

Compound 4, half-maximal effective concentration: 3.89 nM
Compound 4: middle estimate off by 4.3-fold (0.64 log units), on the low side, outside the stated range (above it).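

In this assay, 1,1,2,2,2-pentafluoroethyl in place of nitro on the core of compound 3 gives a 1.4-fold higher number from compound 3 to compound 4 (0.15 log units; within the scatter), so on this read-out the two compounds cannot be told apart. Set beside the earlier step, the size of the change does not carry over from the core of compound 1 to the core of compound 3: the same change on two cores in this assay, a 5.1-fold lower number (0.71 log units; beyond the scatter) from compound 1 to compound 2 and a 1.4-fold higher number (0.15 log units; within the scatter) from compound 3 to compound 4, 7.3-fold (0.86 log units) apart, beyond the scatter of two such steps. With a single pair on each core, this shows that the step seen on one core is no reliable guide to the other in these four compounds, but it does not show which feature of the cores goes with the difference or how the change would behave on a third core.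

The compounds shown leave open whether another group on the same aromatic carbon, such as a nitrile, a trifluoromethyl or an amine, would behave alike on both cores. Also open, from the compounds shown here alone, is whether a core carrying only part of the difference between the two would follow the core of compound 1 or that of compound 3.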